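This account rests on a few compounds, and the source may have more. Where it says the series, first, only, none or still open, it means among the compounds named here.

Values measured so far in a functional assay on LNCaP cells (Homo sapiens) for cytotoxicity, read by MTT assay, with a stated time of 72 h (a lower number here means a stronger inhibitor, a higher number a weaker inhibitor), are as follows.
- compound 1 (`COc1ccc(/C=C/C(=O)/C=C/C2=C(C)CCCC2(C)C)cc1O`) gives 9900 nM
- compound 2 (`COc1ccc(/C=C/C(=O)/C=C/C2=C(C)CCCC2(C)C)cc1OC`) gives 9500 nM
- compound 3 (`CC1=C(/C=C/C(=O)/C=C/c2ccc(C(F)(F)F)cc2)C(C)(C)CCC1`) gives 9100 nM

Compound 3 sits level with the other two. Its value (9100 nM) lies within the usual scatter of those of compound 1 and compound 2, so the three cannot be ranked.

Compound 4 (`CC1=C(/C=C/C(=O)/C=C/c2ccc(F)cc2)C(C)(C)CCC1`) has not yet been measured. It differs from compound 3 in one place, with fluoro in place of trifluoromethyl on an aromatic carbon.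

Within the data shown here, only one measured step exists, and a 1.0-fold lower number from compound 1 to compound 2 (0.02 log units; within the scatter) stays within the scatter. That step is a different change, methyl in place of hydrogen on an oxygen on an aromatic ring, so it offers only indirect guidance. Among the measured compounds shown here, no measured compound carries fluoro, so this swap has no direct precedent. Still, the aromatic ring of compound 3 bears different groups from those of compound 1 and compound 2, and the three values remain alike. No shift beyond the scatter is therefore expected in this assay, in either direction.

The expected step is a 1.0-fold lower number from compound 3 to compound 4 (0.00 log units; within the scatter), which is within the scatter.

For compound 4 the estimated value is 9000 nM, with an expected range from 4500 nM to 18000 nM in repeated measurements.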

Compound 4, half-maximal inhibitory concentration: 7300 nM
For compound 4 the middle estimate is 1.2-fold (0.09 log units) above the measured one; measured number inside the range.
By their numbers in this assay, from the lowest: compounds 4, 3, 2 and 1 (each within the scatter of the next).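

Among these compounds, at the aromatic carbon para to a large group, the swap of trifluoromethyl for fluoro in this assay gives a 1.2-fold lower number from compound 3 to compound 4 (0.10 log units; within the scatter) and is the first measured step at this position. The group goes from 4 heavy atoms to 1 heavy atom, yet the size of the step cannot be told apart from repeat-to-repeat variation, so in this assay this position accepts a much smaller fluorine-bearing group with no detectable effect on the read-out. No supporting measurement is available to explain why the two compounds read alike.

Trifluoromethyl and fluoro both lack hydrogen-bond donors and acceptors, so this single pair cannot show whether the position stays this undemanding when it carries something of a different kind, such as an amine, a carboxylic acid or a longer alkyl chain. On these data alone, whether any group at this carbon can move the number beyond the scatter remains open, as does the result of plain hydrogen there.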